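This account rests on a few compounds, and the source may have more. Where it says the series, first, only, none or still open, it means among the compounds named here.

Series notes, an assay on CHO-K1 cells for displacement of a labelled ligand from adenosine receptor A1 (Homo sapiens), read by scintillation counting, with a stated time of 60 min; a lower number here means a stronger inhibitor, a higher number a weaker inhibitor.

- compound 1 `Nc1nc(N/N=C/c2ccc(-c3ccccn3)cc2)nc2c1ncn2[C@@H]1O[C@H](CO)[C@@H](O)[C@H]1O` gives 7540 nM
- compound 2 `CCCOc1ccc(/C=N/Nc2nc(N)c3ncn([C@@H]4O[C@H](CO)[C@@H](O)[C@H]4O)c3n2)cc1` gives > 10000 nM; for compound 2 this is a limit of the assay, not a number.

Compound 2 stands at the upper end of the two values shown: in this assay it reaches only a limit, (the limit of > 10000 nM in this assay, at which 1 of the 2 values shown sits). Among the compounds with values here, the step of an at least 1.3-fold higher number from compound 1 to compound 2 (0.12 log units; that floor lies within the scatter) is the only measured step in the set, and its floor lies within the scatter, so neither its size nor its direction is settled. Compound 3 `N#Cc1ccc(/C=N/Nc2nc(N)c3ncn([C@@H]4O[C@H](CO)[C@@H](O)[C@H]4O)c3n2)cc1` carries cyano in place of propoxy on an aromatic carbon. Within the data shown here, no measured step touches a cyano group; the one step that exists concerns a different exchange at the same aromatic carbon and offers no foothold beyond the observation that both groups tried so far leave the number high. Expected therefore is no step beyond the scatter in this assay, the step of an at least 1.1-fold lower number from compound 2 to compound 3 (0.04 log units; that floor lies within the scatter) being an estimate only. For compound 3 the estimate is 9000 nM, with a range of 3000 nM to 30000 nM, and a fair chance that again only a limit is reported.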

Compound 3, inhibition constant: 4.1 nM
For compound 3 the middle estimate is 2200-fold (3.34 log units) above the measured one; measured number outside the range, below it.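

In this assay, the group on the aromatic carbon para to a large group decides the result: cyano in place of propoxy gives an at least 2400-fold lower number from compound 2 to compound 3 (3.38 log units; beyond the scatter), and cyano in place of pyridin-2-yl gives a 1800-fold lower number from compound 1 to compound 3 (3.26 log units; beyond the scatter). As far as these compounds go, compound 2 reaches only a limit of the assay, so the first of these steps is a floor and its true size stays unknown: the limit of > 10000 nM in this assay, at which 1 of the 3 values shown sits. The earlier step between propoxy and pyridin-2-yl settled neither size nor direction, whereas a single exchange at this carbon now separates compound 3 from both other compounds by a large margin, so the position is sensitive to the group it carries.

From the compounds shown here alone, whether the low number is particular to the nitrile remains open, and a carboxylic acid, an amide, a chlorine atom or a shorter chain such as methoxy on the same carbon would show how narrow the requirement is. Also open, going by these compounds, is whether the result holds with the cyano group on another carbon of the ring, and whether it extends to any other receptor, since all three values come from this assay.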